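Ethyl for Bromo on the Propoxy Benzamide

The source may report more compounds than this note shows. Statements on the series, on what has been measured and on what is new or still open speak of the compounds shown alone.

Compound 3 `CCCOc1ccc(C(=O)Nc2cccc(Br)n2)cc1` carries a propoxy chain on the shared core, and in an in vitro assay on HEK-tsA201 cells for antagonist activity at Neuronal acetylcholine receptor; alpha3/beta4 (Homo sapiens), read by fluorescence and calcium flux (a higher number here means a weaker inhibitor, a lower number a stronger inhibitor), compound 3 reached only the limit > 100000 nM, so no number is known for it. Its allyloxy counterpart, compound 1 `C=CCOc1ccc(C(=O)Nc2cccc(Br)n2)cc1`, gives 65500 nM in this assay, and the step of an at least 1.5-fold higher number from compound 1 to compound 3 (0.18 log units; that floor lies within the scatter) separates the two. Compound 2 `C=CCOc1ccc(C(=O)Nc2cccc(CC)n2)cc1` carries ethyl in place of bromo on that same allyloxy core and gives 27400 nM in this assay; the step of a 2.4-fold lower number from compound 1 to compound 2 (0.38 log units; beyond the scatter) shows the ethyl group bringing a modest gain.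

Compound 4 `CCCOc1ccc(C(=O)Nc2cccc(CC)n2)cc1` is compound 3 with the same exchange: ethyl in place of bromo on an aromatic carbon. Among the compounds with values here, the only measured step that bears on this change is a 2.4-fold lower number from compound 1 to compound 2 (0.38 log units; beyond the scatter), so a gain of similar size is expected here, in the direction of a stronger inhibitor. The starting point is a limit (the limit of > 100000 nM in this assay, at which 1 of the 3 values shown sits), so the result could again be reported only as a limit rather than as a number. Compound 4 is expected to give about 70000 nM in this assay, with a range from 25000 nM to 200000 nM. The step of an at least 1.4-fold lower number from compound 3 to compound 4 (0.15 log units; that floor lies within the scatter) is thus the expected change.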

Compound 4, half-maximal inhibitory concentration: 29200 nM
Compound 4: the middle estimate sits 2.4-fold (0.38 log units) above what was measured, within the range that was stated.
By their numbers in this assay, from the lowest: compounds 2 and 4 (each within the scatter of the next); then compound 1. At a limit, above all of these: compound 3.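

Compound 3 has only a limit in this assay, > 100000 nM, and that limit is not a number. Ethyl in place of bromo, on the carbon next to the ring nitrogen, gives an at least 3.4-fold lower number from compound 3 to compound 4 (0.53 log units; beyond the scatter), so the change that lowered the number on the allyloxy core also lowers it on the propoxy core, and the step is beyond the scatter on both: the same change on two cores in this assay, a 2.4-fold lower number (0.38 log units; beyond the scatter) from compound 1 to compound 2 and an at least 3.4-fold lower number (0.53 log units; beyond the scatter) from compound 3 to compound 4; the limit leaves it open whether they differ With ethyl at this place, the propoxy and allyloxy chains can now be compared through two real numbers, and a 1.1-fold higher number from compound 2 to compound 4 (0.03 log units; within the scatter) leaves them indistinguishable in this assay, which the bromo pair could not show, though it remains unsettled whether the chain matters more with bromo present: the same change on two cores in this assay, an at least 1.5-fold higher number (0.18 log units; that floor lies within the scatter) from compound 1 to compound 3 and a 1.1-fold higher number (0.03 log units; within the scatter) from compound 2 to compound 4; the limit leaves it open whether they differ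

As far as these compounds go, only bromo and ethyl appear at this place, so it stays open whether a longer chain such as propyl, or an amine, would lower the number further. On the other side of the shared core only propoxy and allyloxy appear, which leaves open how a longer chain such as butoxy would behave with ethyl in place.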